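Chain lengthening on a carbamate and half-life

The source may hold more compounds than are shown below. What is called first, only, known or untested is meant among the compounds shown, and "the series" means these compounds.

Measured compounds:
compound 1, `CCCCNC(=O)Oc1ccc(Cl)cc1C(=O)Nc1cccc(Cl)c1`, 43 h
compound 2, `CCCCCNC(=O)Oc1ccc(Cl)cc1C(=O)Nc1cccc(Cl)c1`, 43 h
compound 3, `CCCCCCCCCCNC(=O)Oc1ccc(Cl)cc1C(=O)Nc1ccc(Cl)cc1`, 43 h

All three were tested in an ADME assay for metabolic stability, read by HPLC, at pH 7.4; a higher number here means that the compound lasts longer, a lower number that the compound disappears faster. Compound 1 gives 43 h, and compound 2, built from it by a small change, gives 43 h. That change is methyl in place of hydrogen on a saturated chain carbon, four bonds along the chain from an amide-type nitrogen, and its step is no change at the digits printed from compound 1 to compound 2 (within the scatter). Compound 3 gives 43 h, so it stands level with compounds 1 and 2 in this assay; the difference between its core and the core of compound 1 is not broken down here.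

Compound 4, `CCCCCCCCCCCNC(=O)Oc1ccc(Cl)cc1C(=O)Nc1ccc(Cl)cc1`, is not yet measured. It arises from compound 3 by methyl in place of hydrogen on a saturated chain carbon, ten or more bonds along the chain from an amide-type nitrogen. This is the same kind of change as that from compound 1 to compound 2, though the place of the added methyl along the chain differs, as the two descriptions of the changes show. Because no change at the digits printed from compound 1 to compound 2 (within the scatter) showed no movement, the step for compound 4 is expected to be no change at the digits printed from compound 3 to compound 4 (within the scatter). Compound 4 is therefore estimated at 43 h, likely between 22 h and 86 h.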

Compound 4, half-life: 43 h
For compound 4 middle estimate and measured number coincide at the digits printed; the range from low to high includes it.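

In this assay, putting methyl in place of hydrogen on a saturated chain carbon, ten or more bonds along the chain from an amide-type nitrogen, gives no change at the digits printed from compound 3 to compound 4 (within the scatter). Set beside the earlier step, the same kind of change behaves alike on the two cores in this assay: the same change on two cores in this assay, no change at the digits printed (within the scatter) from compound 1 to compound 2 and no change at the digits printed (within the scatter) from compound 3 to compound 4, 1.0-fold (0.00 log units) apart, within the scatter of two such steps. For the compounds shown here, this agreement supports carrying the change from one core to the other for this read-out, but it rests on only two pairs, with the methyl at a different place along the chain in each, and it shows neither why the half-life holds steady nor whether the same would be true on a third core or in any other test.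

The compounds shown leave open whether a chain much shorter than butyl, such as methyl or ethyl, would behave the same way. They also leave open what a branched chain, or a chain ending in an amine or a carboxylic acid, would do to the half-life.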